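This account rests on a few compounds, and the source may have more. Where it says the series, first, only, none or still open, it means among the compounds named here.

The measured compounds, each with its value in a physicochemical assay for solubility, at pH 2; a lower number here means a less soluble compound, a higher number a more soluble compound:

Compound 1, `CNc1nc(NCCCN(C)C)c2sc(-c3ccc(NS(C)(=O)=O)cc3)cc2n1`, gives > 100 ug/mL; this is a limit of the assay, not a number.
Compound 2, `CNc1nc(NCCCN(C)C)c2sc(-c3ccc(C(F)(F)F)cc3)cc2n1`, gives 240 ug/mL.

Compound 2 holds the only number shown in this assay. For compound 1 the value is the limit of > 100 ug/mL in this assay, at which 1 of the 2 values shown sits, so a limit and not a number. The step that the limit leaves unreadable from compound 1 to compound 2 cannot be sized.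

Compound 3, `CNc1nc(NCCCN(C)C)c2sc(-c3ccc(C(F)(F)F)cc3Cl)cc2n1`, differs from compound 2 by chloro in place of hydrogen on an aromatic carbon. Among the measured compounds shown here, the only measured step, from compound 1 to compound 2, concerns a different group and its size is not readable, so it offers no guide for the chloro addition. With nothing measured to lean on, the expectation is a small shift in this assay for compound 3, likely downward but not beyond the scatter, which means an estimated step of a 1.6-fold lower number from compound 2 to compound 3 (0.20 log units; within the scatter). Compound 3 is therefore estimated at 150 ug/mL, with a range from 60 ug/mL to 400 ug/mL.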

Compound 3, solubility: > 100 ug/mL
Compound 3: no number, only a limit (the forecaster's own chance of this, stated with the estimate: 10%); the middle value lies beyond the limit too.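

In this assay compound 3 gives > 100 ug/mL, which is a limit and not a number. The step from compound 2 to compound 3 therefore cannot be read, and the same holds for the earlier step from compound 1: the limit of > 100 ug/mL in this assay, at which 2 of the 3 values shown sit.

Going by these compounds, what the chloro group does to the read-out, and where compound 1 and compound 3 truly stand relative to compound 2, stays open.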